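The source may hold more compounds than are shown below. What is called first, only, known or untested is meant among the compounds shown, and "the series" means these compounds.

Measured compounds and their values in a functional assay on SiHa cells (Homo sapiens) for cytotoxicity, read by MTT assay, with a stated time of 48 h; on this read-out higher numbers stand for weaker inhibition and lower numbers for stronger inhibition:
compound 1 `CCCCCCCCNC(=O)[C@@H](NC(=O)c1ccco1)[C@@H](C)O` gives 124000 nM;
compound 2 `CCCCCCCCCCCCCCNC(=O)[C@@H](NC(=O)c1ccco1)[C@@H](C)O` gives 127000 nM;
compound 3 `CCCCCCCCCCCCCCCCCCNC(=O)[C@@H](NC(=O)c1ccccc1)[C@@H](C)O` gives 38200 nM.

Compound 3 stands lowest of the three numbers, beyond the scatter from both compound 1 and compound 2. Compound 4 `CCCCCCCCCCCCCCCCCCNC(=O)[C@@H](NC(=O)c1ccco1)[C@@H](C)O` is reached from compound 3 by one change: furan-2-yl in place of phenyl on a carbonyl carbon. Going by the values given here, no measured pair isolates this ring swap. Among the compounds with values here, the only measured step, a 1.0-fold higher number from compound 1 to compound 2 (0.01 log units; within the scatter), concerns the chain instead and lies within the scatter, so the chain of compound 4 alone gives no reason to expect a shift. What remains is that compound 1 and compound 2, which carry the entering ring on shorter chains, sit higher than compound 3; compound 4 is therefore expected somewhere between those numbers, a step of a 1.8-fold higher number from compound 3 to compound 4 (0.26 log units; within the scatter), giving an estimate of 70000 nM within 25000 nM to 200000 nM.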

Compound 4, half-maximal inhibitory concentration: 13400 nM
Compound 4: the middle estimate sits 5.2-fold (0.72 log units) above what was measured; the whole stated range lies above it.
By their numbers in this assay, from the lowest: compound 4; then compound 3; then compounds 1 and 2 (each within the scatter of the next).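

In this assay, furan-2-yl in place of phenyl on a carbonyl carbon gives a 2.9-fold lower number from compound 3 to compound 4 (0.45 log units; beyond the scatter), so the group at this position matters on the longest chain shown. With furan-2-yl held fixed, the chain also matters once it passes the length in compound 2, with a 9.5-fold lower number from compound 2 to compound 4 (0.98 log units; beyond the scatter) and a 9.3-fold lower number from compound 1 to compound 4 (0.97 log units; beyond the scatter). No measured evidence here explains either step.

Phenyl appears only on the longest chain, leaving open whether the ring swap has the same effect on shorter chains. As far as these compounds go, how a thiophene or pyridine ring at this carbonyl carbon, or a still longer chain, would read also remains open.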